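This account rests on a few compounds, and the source may have more. Where it says the series, first, only, none or still open, it means among the compounds named here.

Compound 1 `CNC(=O)c1cc(C(=O)NCCC2CCOCC2)cn(Cc2ccccc2)c1=O`: in a physicochemical assay for solubility (a lower number here means a less soluble compound, a higher number a more soluble compound), compound 1 gives >= 127 ug/mL, which is a limit of the assay and not a number. Compound 2 `CNC(=O)c1ccc(=O)n(Cc2cc(Br)ccc2F)c1`: in this assay compound 2 gives >= 143 ug/mL, also a limit. Compound 3 `CNC(=O)c1cc(C(=O)NC2CC2)cn(Cc2cccc3[nH]c(C)nc23)c1=O`: in this assay compound 3 gives >= 198 ug/mL, again a limit.

Compound 1 thus stands at a limit (the limit of >= 127 ug/mL in this assay, at which 1 of the 3 values shown sits), and the two other values are limits too, so no ordering among the three is possible. Compound 4 `CNC(=O)c1cc(C(N)=O)cn(Cc2ccccc2)c1=O` differs from compound 1 in one place: hydrogen in place of 2-(oxan-4-yl)ethyl on an amide-type nitrogen. Among the measured compounds shown here, no step between two measured compounds has been recorded, so the size of such a change is not known from these data. The expected step is a step that the limit leaves unreadable from compound 1 to compound 4, within the scatter. Compound 4 is estimated at 150 ug/mL in this assay, likely reported again as a limit. The range for compound 4 is expected to run from 90 ug/mL to 250 ug/mL.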

Compound 4, solubility: 71 ug/mL
For compound 4 the middle estimate is 2.1-fold (0.32 log units) above the measured one; measured number outside the range, below it.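

In this assay, hydrogen in place of 2-(oxan-4-yl)ethyl on the amide-type nitrogen gives an at least 1.7-fold lower number from compound 1 to compound 4 (0.25 log units; that floor lies within the scatter). Compound 4 is the first compound shown with a true number instead of a limit, so this position now has one firm reading. Compound 1 stands at a limit, so the step is only a floor, and it does not clear the usual scatter.

Going by these compounds, how far the true value of compound 1 lies past its limit remains open. So does how a plain ethyl chain or a 2-aminoethyl chain on the same nitrogen would read in this assay.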